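Aryl substituent change on the shared core, compound 4

The source may report more compounds than this note shows. Statements on the series, on what has been measured and on what is new or still open speak of the compounds shown alone.

Compound 3 `c1cn2cc(-c3ccsc3)nc(-c3ccc4ncn(C5CCCCC5)c4c3)c2n1` carries a thiophen-3-yl group on the shared core. In a functional assay on RXF 393 cells (Homo sapiens) for inhibition, read by sulforhodamine B assay, with a stated time of 48 h, tested at 10 uM (on this read-out lower numbers stand for less inhibition and higher numbers for more inhibition at the one concentration tested (going by the name of the read-out)), compound 3 gives 8.63%, the second highest of the three numbers measured; its nearest neighbour is compound 1 `Brc1cn2ccnc2c(-c2ccc3ncn(C4CCCCC4)c3c2)n1`, which in this assay gives 5.58%, a gap within the scatter; the furthest is compound 2 `c1ccc(-c2cn3ccnc3c(-c3ccc4ncn(C5CCCCC5)c4c3)n2)cc1`, which in this assay gives 45%, a gap beyond the scatter.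

Compound 4 `Clc1ccc(-c2cn3ccnc3c(-c3ccc4ncn(C5CCCCC5)c4c3)n2)cc1` differs from compound 3 by 4-chlorophenyl in place of thiophen-3-yl on an aromatic carbon. Among the compounds with values here, two measured steps bear on this. The step of a number 36.4 percentage points lower from compound 2 to compound 3 (beyond the scatter) shows that replacing phenyl, a six-membered ring of carbon only, with thiophen-3-yl removes a large part of the inhibition. The step of a number 39.4 percentage points higher from compound 1 to compound 2 (beyond the scatter) shows that the phenyl group itself brings a large gain over bromo. Within the data shown here, compound 4 returns to a six-membered carbon ring, carrying chlorine; no measured compound bears 4-chlorophenyl, so the chlorine contribution is not known from these data. A rise beyond the scatter is therefore expected in this assay, and the step of a number 36.4 percentage points higher from compound 3 to compound 4 (beyond the scatter) is the estimated size of it. For compound 4 the expected value in this assay is 45%, with a range from 25% to 65%.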

Compound 4, a percentage reported as inhibition, at one concentration (the size of the read-out at that concentration, not a potency): 6.73%
For compound 4 the middle estimate is 38.3 percentage points above the measured one; measured number outside the range, below it.
By their numbers in this assay, from the lowest: compounds 1, 4 and 3 (each within the scatter of the next); then compound 2.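

In this assay chloro in place of hydrogen on an aromatic carbon of the phenyl group of compound 2 gives a lower number: the step of a number 38.3 percentage points lower from compound 2 to compound 4 (beyond the scatter) removes nearly all of the gain that phenyl brought over bromo, so a six-membered aromatic ring of carbon only is not enough by itself to hold the inhibition at this position. The step of a number 1.9 percentage points lower from compound 3 to compound 4 (within the scatter) and the step of a number 1.2 percentage points higher from compound 1 to compound 4 (within the scatter) are both within the scatter, so 4-chlorophenyl cannot be told apart here from thiophen-3-yl or bromo, and among the four compounds only compound 2 stands apart from the rest. No measurement at hand accounts for the large effect of the chlorine in this series.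

Going by these compounds, it stays open whether other groups on the phenyl ring, such as 4-methoxyphenyl or 4-aminophenyl, keep the level of compound 2 or share the low level of compound 4. Also open, on these data alone, is whether a six-membered aromatic ring with nitrogen, such as pyridin-3-yl, would behave like phenyl or like thiophen-3-yl at this position.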